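Sulfonamide nitrogen substitution in a thiourea series

This account rests on a few compounds, and the source may have more. Where it says the series, first, only, none or still open, it means among the compounds named here.

Measured compounds:
compound 1 `NS(=O)(=O)c1ccc(N/C(S)=N\c2ccnc3cc(C(F)(F)F)ccc23)cc1`: 52200 nM
compound 2 `Cc1cc(NS(=O)(=O)c2ccc(N/C(S)=N\c3ccnc4cc(C(F)(F)F)ccc34)cc2)on1`: 28500 nM
compound 3 `Cc1noc(NS(=O)(=O)c2ccc(N/C(S)=N\c3ccnc4cc(C(F)(F)F)ccc34)cc2)c1C`: 36800 nM

In a functional assay on HepG2 cells (Homo sapiens) for antiproliferative activity, read by sulforhodamine B assay, with a stated time of 48 h (a lower number here means a stronger inhibitor, a higher number a weaker inhibitor), compound 1 gives the highest of the three numbers; compound 3 sits nearest and compound 2 furthest, both within the scatter. Compound 4 `O=S(=O)(Nc1nccs1)c1ccc(N/C(S)=N\c2ccnc3cc(C(F)(F)F)ccc23)cc1` differs from compound 1 in one place: 1,3-thiazol-2-yl in place of hydrogen on a sulfonamide nitrogen. For the measured compounds named here, the steps that bear on this are a 1.8-fold lower number from compound 1 to compound 2 (0.26 log units; within the scatter) and a 1.4-fold lower number from compound 1 to compound 3 (0.15 log units; within the scatter), each the entry of an aromatic ring on the same nitrogen, each within the scatter. No step beyond the scatter is therefore expected for compound 4 in this assay. The estimated step is a 1.4-fold lower number from compound 1 to compound 4 (0.14 log units; within the scatter). Compound 4 is expected at 38000 nM, with a range of 15000 nM to 95000 nM.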

Compound 4, half-maximal inhibitory concentration: 28200 nM
Compound 4: the middle estimate sits 1.3-fold (0.13 log units) above what was measured; measured number inside the range.
By their numbers in this assay, from the lowest: compounds 4, 2, 3 and 1 (each within the scatter of the next).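

In this assay, 1,3-thiazol-2-yl on the sulfonamide nitrogen extends the result from the two 1,2-oxazol-5-yl groups to a ring with sulfur, with a 1.9-fold lower number from compound 1 to compound 4 (0.27 log units; within the scatter). Exchanging one ring for another at this nitrogen also stays within the scatter, with a 1.3-fold lower number from compound 3 to compound 4 (0.12 log units; within the scatter) and a 1.0-fold lower number from compound 2 to compound 4 (0.00 log units; within the scatter). No measurement at hand accounts for these small steps. Open, from the compounds shown here alone, is whether a six-membered ring such as pyrimidin-2-yl would give a step beyond the scatter. The same holds for non-ring groups on this nitrogen, such as acetyl or a longer alkyl chain.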